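A few compounds are considered here, and "the series" means these few. Any claim that something is new, unique, unknown or untested is made for them only; others in the source may bear on it.

Measured so far in a functional assay on MDA-MB-231 cells (Homo sapiens) for antiproliferative activity, with a stated time of 4 days; on this read-out higher numbers stand for weaker inhibition and lower numbers for stronger inhibition:
- Compound 1 `CCCCc1ccc2[nH]c(-c3ccc(C(F)(F)F)cc3)c(C=O)c2c1`: 33 nM
- Compound 2 `CCCCc1ccc2[nH]c(-c3ccc(CC)cc3)c(C=O)c2c1`: 27 nM

Going by the values given here, compound 1 and compound 2 lie within the scatter of each other, so compound 1 stands level with the only other measured compound. Compound 3 `CCCCc1ccc2[nH]c(-c3ccc(C(F)(F)F)cc3)c(/C=N/NC(=O)c3ccncc3)c2c1` keeps the core of compound 1 but loses its formyl group: a group of 11 heavy atoms (7 carbon, 3 nitrogen, 1 oxygen; one six-membered aromatic ring with 1 hetero atom) in place of a group of 2 heavy atoms (1 carbon, 1 oxygen; no ring), on an aromatic carbon.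

Among the compounds with values here, the only measured step, a 1.2-fold lower number from compound 1 to compound 2 (0.09 log units; within the scatter), swaps trifluoromethyl for ethyl and leaves the formyl group untouched. Within the data shown here, it therefore gives little guidance on this change, and no measured step covers this place. With a much larger group entering there, a clear move toward weaker inhibition in this assay is expected, though with wide uncertainty. The estimated step is a 7.6-fold higher number from compound 1 to compound 3 (0.88 log units; beyond the scatter). For compound 3 the expected value is 250 nM, with an estimated range of 40 nM to 2000 nM.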

Compound 3, half-maximal inhibitory concentration: 94 nM
Beside the measured number, compound 3's estimate is 2.7-fold (0.42 log units) above it, and the stated range covers the measured number.
By their numbers in this assay, from the lowest: compounds 2 and 1 (each within the scatter of the next); then compound 3.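

Going by these compounds alone, this is the first measured change at this aromatic carbon of the five-membered ring. In this assay, exchanging the formyl group for a much larger group with a six-membered aromatic ring gives a 2.8-fold higher number from compound 1 to compound 3 (0.45 log units; beyond the scatter), a modest loss, and compound 3 still reaches 94 nM, so this position tolerates a group of 11 heavy atoms with only that cost. No available evidence explains the size of this step.

The compounds shown do not reveal which part of the large group accounts for the step, or how a smaller replacement, such as a carboxylic acid or an amine, would behave at this position. From the compounds shown here alone, it also remains open whether the large group would give a similar step with ethyl in place of trifluoromethyl.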